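This account rests on a few compounds, and the source may have more. Where it says the series, first, only, none or still open, it means among the compounds named here.

Three compounds share one core and differ only in the group on the carbonyl carbon. Compound 1 `COc1ccc(C[C@@H](O)/C=C/C=C/C(=O)NCc2ccccc2)cc1OC` carries a benzylamino group there, and in a functional assay on IMR-32 cells (Homo sapiens) for antiproliferative activity, read by sulforhodamine B assay, with a stated time of 48 h (a higher number here means a weaker inhibitor, a lower number a stronger inhibitor), compound 1 gives 16600 nM. Compound 2 `COc1ccc(C[C@@H](O)/C=C/C=C/C(=O)N2CCN(C(c3ccccc3)c3ccccc3)CC2)cc1OC` gives 11900 nM in this assay, and compound 3 `COc1ccc(C[C@@H](O)/C=C/C=C/C(=O)NCc2cc(OC)c(OC)c(OC)c2)cc1OC` gives 13400 nM. Compound 1 shows the highest of the three numbers, yet both others lie within the usual scatter of it, so no real order can be read among them. Compound 4 `COc1ccc(C[C@@H](O)/C=C/C=C/C(=O)N2CCCCC2)cc1OC` differs from compound 1 by piperidin-1-yl in place of benzylamino on a carbonyl carbon. Within the data shown here, no measured pair isolates this kind of change. Given that two other replacements at this carbonyl carbon left the number within scatter, the step of a 1.2-fold lower number from compound 1 to compound 4 (0.07 log units; within the scatter) is expected to be small and without a clear direction. Compound 4 is estimated at 14000 nM, with a range from 6000 nM to 32000 nM.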

Compound 4, half-maximal inhibitory concentration: 11000 nM
Beside the measured number, compound 4's estimate is 1.3-fold (0.10 log units) above it; the measured number falls inside the stated range.
By their numbers in this assay, from the lowest: compounds 4, 2, 3 and 1 (each within the scatter of the next).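

With piperidin-1-yl in place of benzylamino on the carbonyl carbon, the aromatic ring and the hydrogen-bond donor of that group are gone, yet this assay shows only a 1.5-fold lower number from compound 1 to compound 4 (0.18 log units; within the scatter). Among these two compounds, then, neither feature is needed to keep the number at this level, and a smaller group with no aromatic ring is tolerated here. Still open, as far as these compounds go, is whether a morpholine ring, or a piperidine ring bearing a carboxylic acid or an amine, would move the number beyond the scatter. Nothing available explains why this change leaves the number within the scatter.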